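A few compounds are considered here, and "the series" means these few. Any claim that something is new, unique, unknown or untested is made for them only; others in the source may bear on it.

Measured in a functional assay on MKN-45 cells (Homo sapiens) for antiproliferative activity, read by CellTiter-Glo, with a stated time of 3 days; a higher number here means a weaker inhibitor, a lower number a stronger inhibitor:
- compound 1 `C[C@@H](Oc1c(N)ncc2c(-c3cn[nH]c3)coc12)c1c(Cl)ccc(F)c1Cl`: 3300 nM
- compound 2 `COC(=O)N1CC=C(c2coc3c(O[C@H](C)c4c(Cl)ccc(F)c4Cl)c(N)ncc23)CC1`: 850 nM

Among the measured compounds shown here, compound 2 holds the lower of the two numbers, so it is the stronger inhibitor of the pair, and compound 1 is its only neighbour. For the measured compounds named here, the one measured step is a 3.9-fold lower number from compound 1 to compound 2 (0.59 log units; beyond the scatter). It is modest, and it exchanges a whole group on an aromatic carbon.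

Next in the series is compound 3 `C[C@@H](Oc1c(N)ncc2c(C3=CCN(C(=O)N(C)C)CC3)coc12)c1c(Cl)ccc(F)c1Cl`, which differs from compound 2 at a single place: dimethylamino in place of methoxy on a carbonyl carbon. In words, this is dimethylamino in place of methoxy on a carbonyl carbon, or methoxycarbonyl to dimethylcarbamoyl when cut one bond further out.

Going by the values given here, no measured step changes this group, so the data give no direct guide to its effect. The step of a 3.9-fold lower number from compound 1 to compound 2 (0.59 log units; beyond the scatter) bears on it only loosely, as a sign of how far a much larger change at that aromatic carbon moved the number in this assay. A smaller exchange at the far end of the group is therefore expected to give no step beyond the scatter, and the direction is left open. The estimated step is a 1.1-fold lower number from compound 2 to compound 3 (0.03 log units; within the scatter).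

For compound 3 the expected value is 800 nM, with an estimated range of 250 nM to 2500 nM.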

Compound 3, half-maximal inhibitory concentration: 510 nM
Compound 3: the middle estimate sits 1.6-fold (0.20 log units) above what was measured, and the stated range covers the measured number.
By their numbers in this assay, from the lowest: compounds 3 and 2 (each within the scatter of the next); then compound 1.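

In this assay the exchange on the carbonyl carbon gives a 1.7-fold lower number from compound 2 to compound 3 (0.22 log units; within the scatter) and so, unlike the earlier step that replaced the whole group, isolates the far end of the group: dimethylamino and methoxy cannot be told apart at this place. The larger comparison gives a 6.5-fold lower number from compound 1 to compound 3 (0.81 log units; beyond the scatter) and lies beyond the scatter, so a second group with a six-membered non-aromatic ring and a carbonyl end stands apart from the five-membered aromatic ring of compound 1, while compound 2 and compound 3 remain level within the scatter. No supporting measurement bears on this result, and the numbers alone give no account of it.

What the compounds shown leave open is whether the carbonyl on the amide-type ring nitrogen contributes at all, which a free secondary amine or a methylsulfonyl group there would test. They also leave open how much room the far end allows, since a morpholine amide, a pyrrolidine amide or a longer alkyl chain on the carbonyl carbon could move the number beyond the scatter in either direction.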